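A few compounds are considered here, and "the series" means these few. Any claim that something is new, unique, unknown or untested is made for them only; others in the source may bear on it.

Measured compounds:
- Compound 1 `COc1ccc(C(CC(=O)N[C@@H](CC(C)C)B(O)O)NC(=O)c2ccccc2)cc1`: 30900 nM
- Compound 2 `COc1ccc([C@H](CC(=O)N[C@@H](CC(C)C)B(O)O)NC(=O)c2ccccc2)cc1`: 76900 nM

In a functional assay on BCG823 cells (Homo sapiens) for cytotoxicity, read by MTT assay, with a stated time of 72 h (a higher number here means a weaker inhibitor, a lower number a stronger inhibitor), compound 2 stands highest at 76900 nM, so it is the weaker of the two. In compound 3 `COc1ccc([C@@H](CC(=O)N[C@@H](CC(C)C)B(O)O)NC(=O)c2ccccc2)cc1` the change is the two compounds have the same atoms and bonds and differ only in configuration as drawn: 1 of 2 stereo elements differ; a stereocentre at a saturated chain carbon is drawn S in compound 2 and R in compound 3 and it sits at a stereocentre at a saturated chain carbon, drawn S in compound 2 and R in compound 3. Within the data shown here, the one measured step bearing on this is a 2.5-fold higher number from compound 1 to compound 2 (0.40 log units; beyond the scatter), modest in size, and it comes with the fact that one of compounds 1 and 2 is drawn with a defined configuration and the other without, at the place where they differ. If compound 1 holds both forms, its 30900 nM suggests that the R form is the stronger. A lower number is therefore expected in this assay, with an estimated 3.8-fold lower number from compound 2 to compound 3 (0.58 log units; beyond the scatter). Compound 3 is estimated at 20000 nM, within a range of 8000 nM to 50000 nM.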

Compound 3, half-maximal inhibitory concentration: 74400 nM
Compound 3: middle estimate off by 3.7-fold (0.57 log units), on the low side; measured number outside the range, above it.
By their numbers in this assay, from the lowest: compound 1; then compounds 3 and 2 (each within the scatter of the next).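

In this assay, inverting this chain carbon from S to R gives a 1.0-fold lower number from compound 2 to compound 3 (0.01 log units; within the scatter), so the two defined forms cannot be told apart by their numbers and the drawn configuration here shows no effect. Compound 1, drawn without a configuration at this carbon, now differs from both defined forms, with a 2.4-fold higher number from compound 1 to compound 3 (0.38 log units; beyond the scatter). Neither form on its own therefore matches its number.

The compounds shown leave open why compound 1 stands apart. They also leave open whether configuration at this carbon would matter with another group attached, such as a carboxylic acid or an amine.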